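A few compounds are considered here, and "the series" means these few. Any claim that something is new, unique, unknown or untested is made for them only; others in the source may bear on it.

Measured compounds and their half-lives:

Compound 1, `C[C@@H](O)[C@H]1C(=O)N2C(C(=O)O)=C(C(C)(C)C)O[C@H]12`: 8.1 h
Compound 2, `CC(C)(C)C1=C(C(=O)O)N2C(=O)[C@H]([C@H](O)CCc3ccc(O)cc3)[C@H]2O1`: 24.6 h
Compound 3, `CC(C)(C)C1=C(C(=O)O)N2C(=O)[C@H]([C@H](O)CCc3ccncc3)[C@H]2O1`: 13.7 h

In an ADME assay, in phosphate buffer, at 28 degrees C, at pH 7.0 (on this read-out higher numbers stand for a longer-lived compound and lower numbers for a shorter-lived compound), compound 1 gives the lowest of the three numbers. Its nearest neighbour is compound 3, and the step of a 1.7-fold higher number from compound 1 to compound 3 (0.23 log units; within the scatter) lies within the scatter; the step of a 3.0-fold higher number from compound 1 to compound 2 (0.48 log units; beyond the scatter) is the only one beyond it, and it is modest. Compound 4, `COC(=O)[C@H](O)[C@H]1C(=O)N2C(C(=O)O)=C(C(C)(C)C)O[C@H]12`, has not yet been measured in this assay. It differs from compound 1 by hydroxy(methoxycarbonyl)methyl in place of 1-hydroxyethyl on a saturated ring carbon. Going by the values given here, the two measured steps from compound 1 both alter the same side chain, and they are the only guide here: one gave a modest rise and the other no change beyond the scatter. The change to compound 4 is of a different kind, since it replaces rather than extends the chain, so the step is expected to be small in either direction, most likely none beyond the scatter. Compound 4 is therefore expected to give 9 h in this assay, within a range from 4 h to 20 h. That estimate corresponds to the step of a 1.1-fold higher number from compound 1 to compound 4 (0.05 log units; within the scatter).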

Compound 4, half-life: 6.7 h
For compound 4 the middle estimate is 1.3-fold (0.13 log units) above the measured one; measured number inside the range.
By their numbers in this assay, from the lowest: compounds 4, 1, 3 and 2 (each within the scatter of the next, the first and the last beyond it).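

In this assay, the exchange of 1-hydroxyethyl for hydroxy(methoxycarbonyl)methyl on the saturated ring carbon amounts to a 1.2-fold lower number from compound 1 to compound 4 (0.08 log units; within the scatter) and so stays within the scatter. The earlier steps shown here only added 4-hydroxybenzyl or (pyridin-4-yl)methyl to the 1-hydroxyethyl chain, whereas this one shows that the whole group at this position can be exchanged for a larger one carrying a methoxycarbonyl without any shift that can be told from the scatter. No measurement at hand bears on why the number holds.

From the compounds shown here alone, it remains open whether a carboxylic acid or a primary amide in place of the methoxycarbonyl would leave the number equally unmoved. Also open, going by these compounds, is whether a 4-hydroxybenzyl on the hydroxy(methoxycarbonyl)methyl chain would bring the rise seen with compound 2.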